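Swapping the Sulfonamide for Pyridin-3-yl on the Core

The source may hold more compounds than are shown below. What is called first, only, known or untested is meant among the compounds shown, and "the series" means these compounds.

Of the compounds shown here, three sharing one core have been tested in a functional assay on CHO cells for agonist activity at Alpha-1A adrenergic receptor (Homo sapiens), read by FLIPR and calcium flux; on this read-out higher numbers stand for larger maximal responses and lower numbers for smaller maximal responses. Compound 1 `CCCS(=O)(=O)Nc1cccc2c1CCC2c1ncc[nH]1` gives 54%. Compound 2 `c1ccc(-c2cccc3c2CCC3c2ncc[nH]2)nc1` gives 53%, and compound 3 `Cn1ccc(-c2cccc3c2CCC3c2ncc[nH]2)n1` gives 19%. Compound 1 thus stands highest of the three numbers, although compound 2 sits within the scatter of it; only compound 3 falls clearly away, with a number 35 percentage points lower from compound 1 to compound 3 (beyond the scatter).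

Compound 4 `c1cncc(-c2cccc3c2CCC3c2ncc[nH]2)c1` has not yet been measured. Its change from compound 1 is pyridin-3-yl in place of (propylsulfonyl)amino on an aromatic carbon. Going by the values given here, two measured steps bear on this: a number 1 percentage points lower from compound 1 to compound 2 (within the scatter), where pyridin-2-yl took the same place on the core, and a number 35 percentage points lower from compound 1 to compound 3 (beyond the scatter), where 1-methyl-1H-pyrazol-3-yl did. The pyridin-2-yl case is the closer model, as it too brings a six-membered aromatic ring with one hetero atom. For compound 4 in this assay no step beyond the scatter is therefore expected, and the expected step is a number 7 percentage points lower from compound 1 to compound 4 (within the scatter). The range is kept wide, as compound 3 with 19% shows how far a ring in this place can fall. Compound 4 is estimated at 47%, between 22% and 65%.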

Compound 4, largest response reached (Emax), in percent of the reference or control that the assay uses: 36%
Compound 4: middle estimate off by 11 percentage points, on the high side; measured number inside the range.
By their numbers in this assay, from the lowest: compound 3; then compound 4; then compounds 2 and 1 (each within the scatter of the next).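

In this assay, the place of the ring nitrogen matters on this aromatic carbon: going from pyridin-2-yl to pyridin-3-yl gives a number 17 percentage points lower from compound 2 to compound 4 (beyond the scatter), though the two groups differ in nothing else. A six-membered aromatic ring with one hetero atom therefore does not by itself stand in for (propylsulfonyl)amino, since the step from that group to pyridin-3-yl is a number 18 percentage points lower from compound 1 to compound 4 (beyond the scatter), while pyridin-3-yl still keeps a clear margin over 1-methyl-1H-pyrazol-3-yl, with a number 17 percentage points higher from compound 3 to compound 4 (beyond the scatter) as the step. Nothing available explains why the nitrogen's place counts here.

On these data alone, whether pyridin-4-yl or a plain phenyl ring would sit nearer compound 2 or compound 3 stays open. So does how a simple amine or a shorter sulfonamide chain would behave in this place.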